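A few compounds are considered here, and "the series" means these few. Any claim that something is new, unique, unknown or untested is made for them only; others in the source may bear on it.

Compound 1 `CN(C)CCn1cnnc1-c1cc(Oc2ccc(NC(=O)N/N=C/c3ccccc3O[N+](=O)[O-])cc2F)ccn1` and compound 2 `CN(C)CCn1cnnc1-c1cc(Oc2ccc(NC(=O)N/N=C/c3ccc(F)cc3)cc2F)ccn1` share one core and differ only in the aryl group on a carbon with a double bond to nitrogen. In a functional assay on MKN-45 cells (Homo sapiens) for cytotoxicity, read by MTT assay, with a stated time of 72 h (on this read-out lower numbers stand for stronger inhibition and higher numbers for weaker inhibition), compound 1 gives 1020 nM, and compound 2 gives 1030 nM. The step of a 1.0-fold higher number from compound 1 to compound 2 (0.00 log units; within the scatter) shows that exchanging the aryl group at this position left the number within the scatter. Compound 2 stands at the higher of the two numbers, yet its gap to compound 1 is within the scatter, so no order between them can be read. Compound 3 `CN(C)CCn1cnnc1-c1cc(Oc2ccc(NC(=O)N/N=C/c3c(O)ccc4ccccc34)cc2F)ccn1` carries the change (2-hydroxynaphthalen-1-yl in place of 4-fluorophenyl on a carbon with a double bond to nitrogen). Among the compounds with values here, the only measured step that bears on this position, a 1.0-fold higher number from compound 1 to compound 2 (0.00 log units; within the scatter), was flat, so the aryl group swapped here has so far made no difference beyond the scatter. For compound 3 the expected step is a 1.1-fold lower number from compound 2 to compound 3 (0.04 log units; within the scatter), not beyond the scatter. Compound 3 is estimated at 950 nM in this assay, with a range from 300 nM to 3000 nM.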

Compound 3, half-maximal inhibitory concentration: 2020 nM
For compound 3 the middle estimate is 2.1-fold (0.33 log units) below the measured one; the measured number falls inside the stated range.
By their numbers in this assay, from the lowest: compounds 1, 2 and 3 (each within the scatter of the next).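

In this assay, within the data shown here, the first group with a hydroxyl and two fused aromatic rings, 2-hydroxynaphthalen-1-yl, still gives no step that can be read as a difference: a 2.0-fold higher number from compound 2 to compound 3 (0.29 log units; within the scatter) and a 2.0-fold higher number from compound 1 to compound 3 (0.30 log units; within the scatter). Both steps sit at the edge of the scatter but inside it, so compounds 1, 2 and 3 cannot be put in any order, and this position has now taken a hydroxyl-bearing two-ring group as well as two single-ring aryl groups without a shift beyond the scatter. Nothing available explains this flat result.

All three groups on this carbon are aromatic, so the compounds shown leave open what a non-aromatic group would do there. A morpholine ring, a carboxylic acid or a longer alkyl chain could still move the number beyond the scatter.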